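This account rests on a few compounds, and the source may have more. Where it says the series, first, only, none or still open, it means among the compounds named here.

Measured compounds:
- compound 1, `O=C1O[C@]2(CC[C@H](CNc3ccc(-c4cc(F)cc(F)c4)nn3)CC2)CN1c1cccnn1`, 0.016
- compound 2, `O=C1O[C@]2(CC[C@H](CNc3ccc(OC4CCC4)cn3)CC2)CN1c1ccccn1`, "not determined" (no result reported)
- compound 3, `O=C1O[C@]2(CC[C@H](CNc3ccc(-c4ccccc4F)nn3)CC2)CN1c1ccccn1`, 0.016

In an ADME assay on brain (Rattus norvegicus) for protein binding (a lower number here means a smaller unbound share, a higher number a larger unbound share of the compound), compound 1 gives 0.016 and compound 3 gives 0.016; the two numbers are the same, so no order can be read between them. Compound 2 is different: in this assay compound 2 has no single number, its entry reads "not determined" (no result reported), and it therefore stands nowhere on the scale that compounds 1 and 3 occupy.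

The step from compound 2 to compound 4 is a single change on the shared core. Compound 4 is `O=C1O[C@]2(CC[C@H](CNc3ccc(-c4ncccn4)cn3)CC2)CN1c1ccccn1`. The change is pyrimidin-2-yl in place of cyclobutyloxy on an aromatic carbon, para to a large group.

Compound 2 carries no number in this assay. The size and direction of this step therefore cannot be stated from the data; the only anchors are compound 1 and compound 3, whose values are given above. On that basis compound 4 is expected to sit near those two anchors, with a wider band to allow for the new group: compound 4 is estimated at 0.035, between 0.012 and 0.1.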

Compound 4, unbound fraction: 0.035
Compound 4: middle estimate and measured number agree at the digits printed; low and high end bracket the measured number.
By their numbers in this assay, from the lowest: compounds 1 and 3 (each within the scatter of the next); then compound 4.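

In this assay, among the compounds shown here, compound 4 gives 0.035 while compound 2 reads "not determined" (no result reported) so no step from compound 2 to compound 4 can be read. No evidence on hand bears on this result. As far as these compounds go, how far pyrimidin-2-yl in place of cyclobutyloxy moves the number in this assay stays open.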